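The source may report more compounds than this note shows. Statements on the series, on what has been measured and on what is new or still open speak of the compounds shown alone.

Of the compounds shown here, two of a shared core have been tested so far. Compound 1 is `O=C(/C=C\c1ccccc1)N1N=C(c2ccncc2)OC1c1c[nH]c2ccccc12`. In an ADME assay on A549 cells (Homo sapiens) for cytotoxicity, read by MTT assay, with a stated time of 48 h (a higher number here means a weaker inhibitor of growth, a lower number a stronger inhibitor of growth), compound 1 gives > 30 ug/mL, which is a limit of the assay rather than a number. Compound 2 is `COc1ccc(/C=C\C(=O)N2N=C(c3ccncc3)OC2c2c[nH]c3ccccc23)cc1`; it carries a methoxy in place of hydrogen on an aromatic carbon. In this assay compound 2 gives > 30 ug/mL, again a limit and not a number. The step that the two limits leave unreadable from compound 1 to compound 2 therefore cannot be read, because of the limit of > 30 ug/mL in this assay, at which 2 of the 2 values shown sit. On the numbers shown, compound 2 thus stands only at a limit, and the one other value available is a limit too.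

Compound 3 is `O=C(/C=C\c1ccccc1F)N1N=C(c2ccncc2)OC1c1c[nH]c2ccccc12`. Compared with compound 2, the change is 2-fluorophenyl in place of 4-methoxyphenyl on a double-bonded chain carbon bound to a double-bonded chain carbon. Among the measured compounds shown here, the only measured step, from compound 1 to compound 2, concerns the same aromatic ring but has no readable size, so it offers no basis for expecting a shift beyond the usual scatter in this assay. The expected step is a step that the limit leaves unreadable from compound 2 to compound 3. Compound 3 is therefore estimated at 40 ug/mL, with a range from 20 ug/mL to 100 ug/mL.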

Compound 3, concentration for 50% growth inhibition: > 30 ug/mL
Compound 3 was reported as a limit; the forecaster's own chance of this, stated with the estimate: 80%; the middle value lies beyond the limit too.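

The steps among compound 1, compound 2 and compound 3 in this assay cannot be read, because all three results stop at the same limit and not at a number: the limit of > 30 ug/mL in this assay, at which 3 of the 3 values shown sit.

The compounds shown leave open how strongly each inhibits growth, and whether 2-fluorophenyl, 4-methoxyphenyl and the unsubstituted ring differ at all.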